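Lengthening the hydroxycarbamoyl chain of compound 3

The source may report more compounds than this note shows. Statements on the series, on what has been measured and on what is new or still open speak of the compounds shown alone.

In a functional assay on MCF7 cells (Homo sapiens) for inhibition, read by MTT assay, with a stated time of 48 h (a lower number here means a stronger inhibitor, a higher number a weaker inhibitor), compound 1 (`O=C(CCCCCNC(=O)Cn1cnc2c(NCc3ccccc3)ncnc21)NO`) gives > 50000 nM, which is a limit of the assay. Compound 2 (`O=C(CCCCCNC(=O)Cn1cnc2c(Nc3ccccc3)ncnc21)NO`) gives > 50000 nM, also a limit. Compound 3 (`O=C(CCCCNC(=O)Cn1cnc2c(Nc3ccccc3)nc(Nc3ccccc3)nc21)NO`) gives > 50000 nM, again a limit, so it has no numerical position in the series. The measurements so far stand as the limit of > 50000 nM in this assay, at which 3 of the 3 values shown sit.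

The next compound is compound 4 (`O=C(CCCCCNC(=O)Cn1cnc2c(Nc3ccccc3)nc(Nc3ccccc3)nc21)NO`). The change is (hydroxycarbamoyl)methyl in place of hydroxycarbamoyl on a saturated chain carbon, four bonds along the chain from an amide-type nitrogen.

For the measured compounds named here, the only measured step is a step that the two limits leave unreadable from compound 1 to compound 2. It involves a different part of the structure and gives no size to carry over. With no readable step to draw on, no shift beyond the scatter is expected in this assay, and no direction can be assigned. The expected step is a number no higher from compound 3 to compound 4 (the limit leaves the size open). The estimate for compound 4 is 50000 nM, with an expected range from 15000 nM to 100000 nM.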

Compound 4, half-maximal inhibitory concentration: 9580 nM
The estimate for compound 4 lay 5.2-fold (0.72 log units) above the measured number, outside the stated range (below it).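

In this assay, (hydroxycarbamoyl)methyl in place of hydroxycarbamoyl on a saturated chain carbon, four bonds along the chain from an amide-type nitrogen, gives an at least 5.2-fold lower number from compound 3 to compound 4 (0.71 log units; beyond the scatter). With that chain held, anilino in place of hydrogen on an aromatic carbon gives an at least 5.2-fold lower number from compound 2 to compound 4 (0.71 log units; beyond the scatter), so among the compounds shown a reading off the limit appears only where both features are present. For the compounds shown here, compound 4 is the one compound that reads as a number, the others standing at a shared limit: the limit of > 50000 nM in this assay, at which 3 of the 4 values shown sit.

The step from compound 1 to compound 2 cannot be read, and the two readable steps give only a lower bound on their size. Open, on these data alone, are whether 2-(hydroxycarbamoyl)ethyl, a longer chain, lowers the number further at this place and whether a carboxylic acid can stand in for the hydroxycarbamoyl end.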